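Sulfonamide piperidine series: cytotoxicity stays at the limit

The compounds below may be only part of what the source reports. "The series", "measured", "known", "first", "only" and "open" are said of these compounds alone.

The series is read in an ADME assay on HCT-116 cells (Homo sapiens) for cytotoxicity, read by CellTiter-Glo, with a stated time of 72 h; a higher number here means a weaker inhibitor, a lower number a stronger inhibitor. Compound 1 `CCc1ccc(S(=O)(=O)N2CCC(N3CCC(C)CC3)CC2)cc1` gives > 5000 nM, which is a limit of the assay and not a number. Compound 2 `CC1CCN(C2CCN(S(=O)(=O)c3cccc(-c4ccc(F)cc4)c3)CC2)CC1` likewise returns > 5000 nM, again a limit. Compound 3 `COc1ccc(OC)c(S(=O)(=O)N2CCC(N3CCC(C)CC3)CC2)c1` sits at > 5000 nM, a limit as well. Across the three measured compounds no numerical value is available: every reading rests at the same limit, as recorded in the limit of > 5000 nM in this assay, at which 3 of the 3 values shown sit, so compound 3 stands no higher and no lower than the others on the numbers shown, and no step between measured compounds can be sized.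

Compound 4 `COc1cccc(S(=O)(=O)N2CCC(N3CCC(C)CC3)CC2)c1` is not yet measured. It differs from compound 3 as follows (hydrogen in place of methoxy on an aromatic carbon). Among the measured compounds shown here, with no measured step available and all three readings at the same limit, no change beyond the scatter is expected in this assay from this step. Compound 4 is therefore expected to give 8000 nM (range 4000 nM to 30000 nM), most probably reported as a limit rather than a number. The implied step that the limit leaves unreadable from compound 3 to compound 4 is expected to be essentially none.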

Compound 4, half-maximal inhibitory concentration: > 5000 nM
Compound 4: a limit, no number (the forecaster's own chance of this, stated with the estimate: 85%); the middle value lies beyond the limit too.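

The steps to compound 4 from compound 1, compound 2 and compound 3 cannot be read, and no new step follows: the limit of > 5000 nM in this assay, at which 4 of the 4 values shown sit.

The compounds shown leave open whether any change on the shared core gives a numerical reading in this assay, and how large such a change would be.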